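This account rests on a few compounds, and the source may have more. Where it says the series, first, only, none or still open, it means among the compounds named here.

Compound 1 `COc1ccc(-c2cnc(NC(=O)c3ccn[nH]3)n2C)cc1`: in a toxicity assay on THP-1 cells (Homo sapiens) for inhibition (on this read-out higher numbers stand for lower toxicity in this test and lower numbers for higher toxicity in this test), compound 1 gives > 100000 nM, which is a limit of the assay and not a number.
Compound 2 `COc1ccc(-c2cnc(NC(=O)c3cc(-c4ccccn4)n[nH]3)n2C)cc1`: in this assay compound 2 gives >= 50000 nM, also only a limit.
Compound 3 `COc1ccc(-c2cnc(NC(=O)c3ccc(C)cc3)n2C)cc1`: not yet measured.

Among the compounds with values here, compound 1 stands only at a limit in this assay; the single further value shown is likewise a limit, so no number places it. Within the data shown here, the one measured step, a step that the two limits leave unreadable from compound 1 to compound 2, stays unreadable because of the limit of > 100000 nM in this assay, at which 1 of the 2 values shown sits, and (the limit of >= 50000 nM in this assay, at which 1 of the 2 values shown sits). Compound 3 differs from compound 1 by 4-methylphenyl in place of 1H-pyrazol-5-yl on a carbonyl carbon. Among the measured compounds shown here, no measured step touches the group on the carbonyl carbon in a readable way, so nothing points to a step in this assay beyond the scatter in either direction. Compound 3 is therefore expected at about 100000 nM, within 30000 nM to 300000 nM, most likely again reported only as a limit near the level of compound 1. The step of a number no higher from compound 1 to compound 3 (the limit leaves the size open) is expected to be essentially none.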

Compound 3, half-maximal cytotoxic concentration: > 100000 nM
Compound 3: no number, only a limit; the forecaster's own chance of this, stated with the estimate: 75%; the middle value lies on the limit itself.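

The result for compound 3, like that for compound 1, is only a limit in this assay, so no step can be read between these two compounds: the limit of > 100000 nM in this assay, at which 2 of the 3 values shown sit.

The compounds shown leave open what 4-methylphenyl in place of 1H-pyrazol-5-yl on a carbonyl carbon changes in this assay, and whether any of them would give an actual number there.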